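Replacing a Cyclohexylamino Chain with a Hydroxylated Benzyl Group

The source may hold more compounds than are shown below. What is called first, only, known or untested is meant among the compounds shown, and "the series" means these compounds.

Measured so far, in an assay on HEK293 cells for displacement of a labelled ligand from Melanocortin receptor 4 (Homo sapiens); on this read-out lower numbers stand for stronger inhibition and higher numbers for weaker inhibition:
compound 1, `COc1cc(CC(C)C(=O)N2CCN(c3ccc(C(F)(F)F)cc3[C@@H](N)CC(C)C)CC2)ccc1Cl`, gives 230 nM;
compound 2, `CC(C)C[C@H](N)c1cc(C(F)(F)F)ccc1N1CCN(C(=O)C(C)Cc2ccc(Cl)cc2)CC1`, gives 47 nM;
compound 3, `CC(C)C[C@H](N)c1cc(C(F)(F)F)ccc1N1CCN(C(=O)CCNC2CCCCC2)CC1`, gives 4800 nM.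

Among these three, compound 3 stands at the highest number, that is the weakest binding. Its nearest neighbour is compound 1, and a 21-fold higher number from compound 1 to compound 3 (1.32 log units; beyond the scatter); further away is compound 2, and a 100-fold higher number from compound 2 to compound 3 (2.01 log units; beyond the scatter).

The next compound, compound 4, `CC(C)C[C@H](N)c1cc(C(F)(F)F)ccc1N1CCN(C(=O)C(C)Cc2ccc(Cl)cc2O)CC1`, is reached from compound 3 by one change: 1-(4-chloro-2-hydroxybenzyl)ethyl in place of 2-(cyclohexylamino)ethyl on a carbonyl carbon. The two measured steps that bear on this are the reverse of those just named, since both replaced a benzyl-bearing branch on the same carbonyl carbon with the cyclohexylamino chain, and both gave large rises in the number. Compound 4 carries a benzyl-bearing branch again, this time with a hydroxyl on the aromatic ring, so a large fall in the number is expected, landing between the values of compound 1 and compound 2; the comparison a 4.9-fold lower number from compound 1 to compound 2 (0.69 log units; beyond the scatter) shows that a single substituent on that ring can shift the outcome modestly. For compound 4 the estimate is 100 nM, in the range 30 nM to 350 nM, and the expected step is a 48-fold lower number from compound 3 to compound 4 (1.68 log units; beyond the scatter).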

Compound 4, inhibition constant: 36 nM
Compound 4: middle estimate off by 2.8-fold (0.44 log units), on the high side; low and high end bracket the measured number.
By their numbers in this assay, from the lowest: compounds 4 and 2 (each within the scatter of the next); then compound 1; then compound 3.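

Putting the 1-(4-chloro-2-hydroxybenzyl)ethyl group on the carbonyl carbon in place of the cyclohexylamino chain brings a 130-fold lower number from compound 3 to compound 4 (2.12 log units; beyond the scatter) in this assay, so the aromatic branch keeps its large advantage over that chain even when its ring carries a hydroxy group. The hydroxy group itself leaves the read-out unchanged, with a 1.3-fold lower number from compound 2 to compound 4 (0.12 log units; within the scatter) lying within the usual scatter, so this aromatic ring accepts hydroxy in place of hydrogen without a measurable loss, unlike the methoxy-bearing ring of compound 1. The swap of 4-chloro-3-methoxyphenyl for 4-chloro-2-hydroxyphenyl gives a 6.4-fold lower number from compound 1 to compound 4 (0.81 log units; beyond the scatter) and shows a real difference between those two rings, although no measurement at hand explains it.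

The compounds shown leave open whether an amine or a carboxylic acid on this aromatic ring, in place of the hydroxy group, would keep the number close to that of compound 4. They also do not tell whether a longer chain joining the ring to the carbonyl carbon would keep it there.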